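The source may hold more compounds than are shown below. What is called first, only, known or untested is meant among the compounds shown, and "the series" means these compounds.

Measured compounds:
compound 1 `O=C(CCc1ccccc1)NCCCNc1nc(Nc2cccc(F)c2)ncc1Br` — 560 nM
compound 2 `CC(=O)N1CCC(C(=O)NCCCNc2nc(Nc3cccc(F)c3)ncc2Br)CC1` — 430 nM
compound 3 `COCCC(=O)NCCCNc1nc(Nc2cccc(F)c2)ncc1Br` — 60 nM

In an assay on isolated protein for inhibition of serine/threonine-protein kinase TBK1 (Homo sapiens) (a higher number here means a weaker inhibitor, a lower number a stronger inhibitor), compound 3 holds the lowest of the three numbers; the steps of a 9.3-fold lower number from compound 1 to compound 3 (0.97 log units; beyond the scatter) and a 7.2-fold lower number from compound 2 to compound 3 (0.86 log units; beyond the scatter) both lie beyond the scatter, so compound 3 is the strongest inhibitor measured so far.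

Compound 4 `CN1CCC(C(=O)NCCCNc2nc(Nc3cccc(F)c3)ncc2Br)CC1` is not yet measured. Its change from compound 3: 1-methylpiperidin-4-yl in place of 2-methoxyethyl on a carbonyl carbon. The bearing step is a 7.2-fold lower number from compound 2 to compound 3 (0.86 log units; beyond the scatter), which runs the opposite way, from a ring of this kind to 2-methoxyethyl; the step of a 1.3-fold lower number from compound 1 to compound 2 (0.11 log units; within the scatter) shows the acetylated ring and phenethyl within scatter of each other. A modest rise is therefore expected, a 5.0-fold higher number from compound 3 to compound 4 (0.70 log units; beyond the scatter). For compound 4 the estimate in this assay is 300 nM, range 100 nM to 900 nM.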

Compound 4, half-maximal inhibitory concentration: 4300 nM
Beside the measured number, compound 4's estimate is 14-fold (1.16 log units) below it, and the stated range ends below it.
By their numbers in this assay, from the lowest: compound 3; then compounds 2 and 1 (each within the scatter of the next); then compound 4.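

Among these compounds, at this carbonyl carbon the group on the ring amine nitrogen matters: a 10-fold higher number from compound 2 to compound 4 (1.00 log units; beyond the scatter) with methyl in place of acetyl, a difference that the earlier compounds could not show. Among the compounds shown here, compound 4 is the weakest inhibitor of the four in this assay, with a 7.7-fold higher number from compound 1 to compound 4 (0.89 log units; beyond the scatter) and a 72-fold higher number from compound 3 to compound 4 (1.86 log units; beyond the scatter) as the largest step so far. Nothing measured here gives a cause for these steps.
Open, on these data alone, is how a piperidine ring bearing only hydrogen on its nitrogen, or a methyl sulfonamide there, would compare, and whether a longer methoxyalkyl chain would hold the number of compound 3.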